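Removing the fluoro group from a benzyl ether

The source may hold more compounds than are shown below. What is called first, only, known or untested is meant among the compounds shown, and "the series" means these compounds.

Compound 1, `CCCCCCOc1ccc2c(Cl)ccnc2c1`, in a functional assay on DLD-1 cells (Homo sapiens) for cytotoxicity, read by MTT assay, with a stated time of 48 h (a higher number here means a weaker inhibitor, a lower number a stronger inhibitor), gives 2660 nM.
Compound 2, `CC(C)COc1ccc2c(Cl)ccnc2c1`, gives 3100 nM.
Compound 3, `Fc1ccc(COc2ccc3c(Cl)ccnc3c2)cc1`, gives 3230 nM.

Compound 3 carries the highest number of the three, yet its gaps to compound 2 and to compound 1 are both within the scatter, so no order among the three can be read from these values. Compound 4, `Clc1ccnc2cc(OCc3ccccc3)ccc12`, differs from compound 3 by hydrogen in place of fluoro on an aromatic carbon. Among the compounds with values here, only one step between measured compounds is known, a 1.2-fold higher number from compound 1 to compound 2 (0.07 log units; within the scatter), and it concerns the saturated chain on the oxygen rather than the aromatic ring, so it does not bear directly on the present change; it shows only that the series has so far moved little. Nothing in the measured compounds speaks to exchanging fluoro for hydrogen on an aromatic carbon. Compound 4 is therefore expected to sit close to compound 3, with the step of a 1.0-fold lower number from compound 3 to compound 4 (0.00 log units; within the scatter) expected to stay within the scatter. The estimate for compound 4 is 3200 nM, with a range from 1600 nM to 6500 nM.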

Compound 4, half-maximal inhibitory concentration: 3270 nM
Estimate against measurement, compound 4: 1.0-fold (0.01 log units) below; the range from low to high includes it.
By their numbers in this assay, from the lowest: compounds 1, 2, 3 and 4 (each within the scatter of the next).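

Hydrogen in place of fluoro on an aromatic carbon para to a large group gives a 1.0-fold higher number from compound 3 to compound 4 (0.01 log units; within the scatter) in this assay and so, at this position, the fluoro can be lost with no readable change. The unsubstituted benzyl ether also opens the comparison with the saturated chains, where phenyl in place of isopropyl gives a 1.1-fold higher number from compound 2 to compound 4 (0.02 log units; within the scatter) and phenyl in place of pentyl gives a 1.2-fold higher number from compound 1 to compound 4 (0.09 log units; within the scatter) so that compound 4 cannot be told apart from either compound 1 or compound 2. No measured evidence bears on why these numbers stay together.

From the compounds shown here alone, whether an amine, a carboxylic acid or a methoxy group on that same aromatic carbon would carry the number beyond the scatter remains open. So does whether a longer chain on the oxygen would do so.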